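Compound 4: Cyclohexyl in Place of Isopropyl

A few compounds are considered here, and "the series" means these few. Any claim that something is new, unique, unknown or untested is made for them only; others in the source may bear on it.

Compound 1 `CCN1CCc2c(sc(N)c2C(N)=O)C1`, compound 2 `CC(C)CN1CCc2c(sc(NC(=O)Nc3ccc(Cl)cc3)c2C(N)=O)C1` and compound 3 `CCN1CCc2c(ccc(NC(=O)Nc3ccc(Cl)cc3)c2C(N)=O)C1` were examined in a functional assay (strain AB) with Danio rerio as the target, read by microscopy, with a stated time of 1 h; a higher number here means that more compound is needed for the effect, a lower number that less compound is needed. In this assay compound 1 reaches only the limit > 25000 nM. Compound 3 likewise gives only the limit > 25000 nM. Among the compounds with values here, compound 2 is the single member with a number, 4510 nM, and so stands alone as the one measured value. The other two entries sit at the limit of > 25000 nM in this assay, at which 2 of the 3 values shown sit. Compound 4 `NC(=O)c1c(NC(=O)Nc2ccc(Cl)cc2)sc2c1CCN(CC1CCCCC1)C2` has not yet been measured; it differs from compound 2 by cyclohexyl in place of isopropyl on a saturated chain carbon bound to an amine nitrogen in a ring. Within the data shown here, no measured pair follows this change, so the expectation rests on compound 2 alone. Compound 4 is expected near 3000 nM, between 900 nM and 10000 nM. The step from compound 2 to compound 4 is expected to be a 1.5-fold lower number from compound 2 to compound 4 (0.18 log units; within the scatter), not clearly beyond the scatter.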

Compound 4, half-maximal effective concentration: 1890 nM
For compound 4 the middle estimate is 1.6-fold (0.20 log units) above the measured one; the measured number falls inside the stated range.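

In this assay, within the data shown here, the change of isopropyl to cyclohexyl gives a 2.4-fold lower number from compound 2 to compound 4 (0.38 log units; beyond the scatter) and so offers the first reading of this position, on a saturated chain carbon bound to an amine nitrogen in a ring. The position accepts a six-membered ring of carbon only, and the number moves modestly lower rather than higher. Nothing shown explains this step. Going by these compounds, it remains open whether a phenyl ring or a longer chain would lower the number further at this position. On these data alone, it is also open how an amine or a carboxylic acid on the cyclohexyl ring would change it.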